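Trimming the tert-butyl of compound 2 down to ethyl

A few compounds are considered here, and "the series" means these few. Any claim that something is new, unique, unknown or untested is made for them only; others in the source may bear on it.

Of the compounds shown here, three sharing one core have been measured in a physicochemical assay for solubility, at pH 6.8; a higher number here means a more soluble compound, a lower number a less soluble compound. Compound 1 `Cc1c(C(C)(C)C)c(N2CC[C@H](N(C)C)C2)n2nc(C(C)(C)C)nc2c1C#N` gives 146 ug/mL. Compound 2 `Cc1c(-c2ccccc2)c(N2CC[C@H](N(C)C)C2)n2nc(C(C)(C)C)nc2c1C#N` gives 16 ug/mL, and compound 3 `Cc1c(-c2ccccc2)c(N2CC[C@H](N(C)C)C2)n2nc(C(C)(C)CO)nc2c1C#N` gives 140 ug/mL. Compound 2 thus stands lowest of the three: the step of a 9.1-fold lower number from compound 1 to compound 2 (0.96 log units; beyond the scatter) took the number down, and the step of an 8.8-fold higher number from compound 2 to compound 3 (0.94 log units; beyond the scatter) brought it back up to roughly where compound 1 sits.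

Compound 4 `CCc1nc2c(C#N)c(C)c(-c3ccccc3)c(N3CC[C@H](N(C)C)C3)n2n1` has not yet been measured. It differs from compound 2 in one place: ethyl in place of tert-butyl on an aromatic carbon. Neither measured step matches this change exactly. The step from compound 1 to compound 2 altered a different ring position, and the step from compound 2 to compound 3 kept the tert-butyl and only added a hydroxy to it. Both, however, were modest in size, so a modest step is the reasonable expectation here too, and with fewer carbon atoms in the group the direction is expected to be upward rather than downward. For compound 4 the expected step is a 2.2-fold higher number from compound 2 to compound 4 (0.34 log units; beyond the scatter). Compound 4 is therefore estimated at 35 ug/mL, within a range of 15 ug/mL to 85 ug/mL.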

Compound 4, solubility: 228 ug/mL
Beside the measured number, compound 4's estimate is 6.5-fold (0.81 log units) below it; the measured number lies above the stated range.
By their numbers in this assay, from the lowest: compound 2; then compounds 3, 1 and 4 (each within the scatter of the next).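

In this assay, for the compounds shown here, the group on this aromatic carbon, between two ring nitrogen atoms, proves able to move the number further than either earlier change did: ethyl in place of tert-butyl gives a 14-fold higher number from compound 2 to compound 4 (1.15 log units; beyond the scatter) and is the only step so far marked as large. Going by these compounds alone, neither group carries a hydrogen-bond donor or acceptor, so a rise of this size at this carbon does not depend on adding a hydroxy, which was the only change made here before. Ethyl and 1-(hydroxymethyl)-1-methylethyl are two different replacements for tert-butyl, and the comparison between them gives a 1.6-fold higher number from compound 3 to compound 4 (0.21 log units; within the scatter), so this assay cannot tell them apart.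

The compounds shown leave open whether methyl, a longer chain such as n-butyl or an amine on this carbon would give a similar number, and whether ethyl would have the same effect with tert-butyl rather than phenyl on the other ring position, as in compound 1. No measurement at hand accounts for the size of the step from tert-butyl to ethyl.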